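Butyl to 3-Fluorophenyl Amide: Expected Cytotoxicity of Compound 4

The source may report more compounds than this note shows. Statements on the series, on what has been measured and on what is new or still open speak of the compounds shown alone.

Three compounds have been measured in an ADME assay on SW480 cells (Homo sapiens) for cytotoxicity, read by MTT assay, with a stated time of 72 h; on this read-out higher numbers stand for weaker inhibition and lower numbers for stronger inhibition:
Compound 1 `CCCCCN1C(=O)C/C(=C\c2cccc(C(=O)Nc3ccc(C)cc3)c2)C1=O` gives only a limit, > 100000 nM.
Compound 2 `O=C(Nc1cccc(F)c1)c1cccc(/C=C2\CC(=O)N(c3ccccc3)C2=O)c1` gives only a limit, > 100000 nM.
Compound 3 `CCCCCN1C(=O)C/C(=C\c2cccc(C(=O)NCCCC)c2)C1=O` gives only a limit, > 100000 nM.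

Compound 3 therefore stands at the edge of what this assay can report, and it shares that position with every other measured compound (the limit of > 100000 nM in this assay, at which 3 of the 3 values shown sit). Going by the values given here, the one single-point step available, a step that the two limits leave unreadable from compound 1 to compound 3, is unreadable for the same reason, so no measured step shows how an amide substituent shifts the read-out. Compound 4 `CCCCCN1C(=O)C/C(=C\c2cccc(C(=O)Nc3cccc(F)c3)c2)C1=O` differs from compound 3 by 3-fluorophenyl in place of butyl on an amide-type nitrogen. Compound 2 carries the same (3-fluorophenyl)amino group on a different core and likewise reached only the limit. Compound 4 is expected to show no step beyond the scatter, a step that the limit leaves unreadable from compound 3 to compound 4. Compound 4 is estimated at 150000 nM, within 60000 nM to 400000 nM.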

Compound 4, half-maximal inhibitory concentration: > 100000 nM
Compound 4 gave a limit, no number; the forecaster's own chance of this, stated with the estimate: 80%; the middle value lies beyond the limit too.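

No new step can be read between compound 4 and compound 1, compound 2 or compound 3, because each gives only a limit: the limit of > 100000 nM in this assay, at which 4 of the 4 values shown sit.

Whether any amide substituent shown changes the read-out in this assay stays open.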